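A few compounds are considered here, and "the series" means these few. Any claim that something is new, unique, unknown or untested is made for them only; others in the source may bear on it.

Measured compounds:
compound 1 `CSC1N=CNc2c(C)nc(C)n21` with 440000 nM
compound 2 `Cc1ncn2c1NC=NC2N` with 746000 nM

In a functional assay on CCRF-CEM cells (Homo sapiens) for cytotoxicity (a lower number here means that less compound is tolerated, a higher number that more compound is tolerated), compound 2 gives 746000 nM, and compound 1 gives 440000 nM. Among the compounds with values here, these two values lie within the scatter of each other, so the data give no ranking of the pair; both sit at high concentrations, meaning large amounts of either compound are tolerated by the cells.

Compound 3 `Cc1nc(C)n2c1NC=NC2N` has not yet been tested in this assay. It differs from compound 2 by a small change: methyl in place of hydrogen on an aromatic carbon, a methyl in place of hydrogen on an aromatic carbon, placed between two ring nitrogen atoms of the five-membered ring. Within the data shown here, no measured pair here isolates this change, so nothing in the data shows its effect. Given that the two measured values already agree within scatter, no step beyond the scatter is expected from compound 2 to compound 3. Compound 3 is therefore estimated at 600000 nM, within the range 250000 nM to 1400000 nM, which means an expected step of a 1.2-fold lower number from compound 2 to compound 3 (0.09 log units; within the scatter).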

Compound 3, half-maximal cytotoxic concentration: 115000 nM
Estimate against measurement, compound 3: 5.2-fold (0.72 log units) above; measured number below the stated range.
By their numbers in this assay, from the lowest: compound 3; then compounds 1 and 2 (each within the scatter of the next).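

In this assay, a methyl in place of hydrogen on an aromatic carbon, between two ring nitrogen atoms, gives a 6.5-fold lower number from compound 2 to compound 3 (0.81 log units; beyond the scatter) and so means that the cells tolerate less compound; this position of the five-membered ring is therefore sensitive to even this one added carbon when an amino group sits on the saturated ring carbon. With that methyl present, amino in place of methylsulfanyl on the saturated ring carbon gives a 3.8-fold lower number from compound 1 to compound 3 (0.58 log units; beyond the scatter), so the group at that second place also counts. Nothing shown here gives a reason for either step.

On these data alone, it stays open whether the methyl would have a similar effect with methylsulfanyl on the saturated ring carbon. As far as these compounds go, it is also open what an ethyl group, a chlorine atom or a carboxylic acid would do at the position between the two ring nitrogen atoms.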